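A few compounds are considered here, and "the series" means these few. Any claim that something is new, unique, unknown or untested is made for them only; others in the source may bear on it.

Working notes on the series.

Three analogues of the shared core carry a measurement in a functional assay on BT-474 cells (Homo sapiens) for inhibition, read by fluorescence, with a stated time of 72 h; on this read-out lower numbers stand for stronger inhibition of growth and higher numbers for weaker inhibition of growth. Compound 1, `CC(C)CCn1cnc2c(NCc3cccc(Cl)c3)nc(N[C@H]3CC[C@H](N)CC3)nc21`, gives 6600 nM. Compound 2, `CC(C)=CCC/C(C)=C/Cn1cnc2c(Nc3cccc(Cl)c3)nc(N[C@H]3CC[C@H](N)CC3)nc21`, gives 4300 nM, and compound 3, `CCCCn1cnc2c(Nc3ccccc3)nc(N[C@H]3CC[C@H](N)CC3)nc21`, gives 4900 nM. Compound 1 holds the largest number of the three, but its gaps to compound 3 and to compound 2 both fall within the usual scatter of repeated measurements, so the three compounds cannot be told apart on these numbers, and no ordering among them is supported.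

Compound 4, `COc1ccc(Nc2nc(N[C@H]3CC[C@H](N)CC3)nc3c2ncn3CCC(C)C)c(OC)c1`, has not yet been measured. Relative to compound 1 the change is 2,4-dimethoxyphenyl in place of 3-chlorobenzyl on a nitrogen on an aromatic ring. Compound 2 and compound 3 both already carry an aromatic ring directly on the same nitrogen and sit where compound 1 sits, so nothing in the measured set points to a shift beyond the scatter in either direction; the step from compound 1 to compound 4 is expected to be small, close to no change, as a 1.2-fold lower number from compound 1 to compound 4 (0.08 log units; within the scatter). On that basis compound 4 is estimated at 5500 nM in this assay, with a range from 2000 nM to 15000 nM.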

Compound 4, concentration for 50% growth inhibition: 7900 nM
Estimate against measurement, compound 4: 1.4-fold (0.16 log units) below, and the stated range covers the measured number.
By their numbers in this assay, from the lowest: compounds 2, 3, 1 and 4 (each within the scatter of the next).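

The pair gives the series its first comparison in one place: in this assay, 2,4-dimethoxyphenyl in place of 3-chlorobenzyl on a nitrogen on an aromatic ring reads as a 1.2-fold higher number from compound 1 to compound 4 (0.08 log units; within the scatter). The exchange removes the chlorine and brings in hydrogen-bond acceptors that the leaving group lacks, yet on this pair the number does not move beyond the scatter, which compounds 2 and 3, each differing from compound 1 in more than one place, could not show. Nothing measured here bears on the reason for this result.

The compounds shown leave open whether the carbon link of the benzyl group and the substituents on its ring would each leave the number within the scatter if changed singly, as a comparison with 2,4-dimethoxybenzyl on the same nitrogen would show. Also open, on these data alone, is whether any group at this position moves the number beyond the scatter in either direction, for instance a carboxylic acid or a dimethylamino group on the aromatic ring.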